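A few compounds are considered here, and "the series" means these few. Any claim that something is new, unique, unknown or untested is made for them only; others in the source may bear on it.

Compound 1 `CCOCn1c(Cc2ccccc2)c(Br)c(=O)[nH]c1=O`: 155000 nM
Compound 2 `O=c1[nH]c(=O)n(COCc2ccccc2)c(Cc2ccccc2)c1Br`: 67400 nM
Compound 3 `Cc1cc(C)cc(Cc2c(Br)c(=O)[nH]c(=O)n2COCc2ccccc2)c1`: 152000 nM

In an ADME assay on MT4 cells (Homo sapiens) for cytotoxicity, read by XTT assay, with a stated time of 3 days (on this read-out lower numbers stand for higher toxicity in this test and higher numbers for lower toxicity in this test), compound 2 gives 67400 nM, the lowest of the three numbers. Compound 4 `CN(C)c1c(Cc2ccccc2)n(COCc2ccccc2)c(=O)[nH]c1=O` is not yet measured and differs from compound 2 in one place, with dimethylamino in place of bromo on an aromatic carbon. Neither measured step touches the bromo group. Both a 2.3-fold lower number from compound 1 to compound 2 (0.36 log units; beyond the scatter) and a 2.3-fold higher number from compound 2 to compound 3 (0.35 log units; beyond the scatter) lie elsewhere on the molecule and are modest, so they offer a sense of scale but no direction for this change. Little movement beyond the scatter is therefore expected. The estimated change is a 1.3-fold higher number from compound 2 to compound 4 (0.13 log units; within the scatter). For compound 4 the estimated value is 90000 nM, with an expected range from 30000 nM to 250000 nM.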

Compound 4, half-maximal cytotoxic concentration: 91800 nM
Estimate against measurement, compound 4: 1.0-fold (0.01 log units) below; the measured number falls inside the stated range.
By their numbers in this assay, from the lowest: compounds 2, 4, 3 and 1 (each within the scatter of the next, the first and the last beyond it).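

This is the first change shown at this position of the shared core: dimethylamino in place of bromo gives a 1.4-fold higher number from compound 2 to compound 4 (0.13 log units; within the scatter) in this assay. A group of three heavy atoms, including a nitrogen, can therefore replace a single bromine here without moving the number beyond the usual scatter. Nothing measured here explains this result.

On these data alone, it remains open whether a smaller amine, a carboxylic acid or a longer chain at this position would also stay within the scatter of compound 2. As far as these compounds go, the same exchange on compound 1 or compound 3 also remains open.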